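The source may report more compounds than this note shows. Statements on the series, on what has been measured and on what is new or still open speak of the compounds shown alone.

Compound 1 `Cc1cnc(Nc2ccc(C#N)cc2)nc1Nc1c(F)cc(-c2ccco2)cc1F`: 8100 nM
Compound 2 `Cc1cc(-c2cncnc2)cc(C)c1Nc1ccnc(Nc2ccc(C#N)cc2)n1`: 6800 nM

In a toxicity assay on MT4 cells (Homo sapiens) for cytotoxicity, read by MTT assay, with a stated time of 5 days (on this read-out lower numbers stand for higher toxicity in this test and higher numbers for lower toxicity in this test), compound 1 gives 8100 nM and compound 2 gives 6800 nM, two numbers that lie within the usual scatter of each other. Compound 3 `Cc1cc(-c2cc(C)c(Nc3ccnc(Nc4ccc(C#N)cc4)n3)c(C)c2)ccn1` follows from compound 2 with 2-methylpyridin-4-yl in place of pyrimidin-5-yl on an aromatic carbon. Among the measured compounds shown here, no measured pair here differs in one place, so the data offer no direct guide to the size of such a step. No change beyond the scatter is expected, and the estimated step is a 1.2-fold lower number from compound 2 to compound 3 (0.09 log units; within the scatter). For compound 3 the expected value is 5500 nM, with an estimated range of 2000 nM to 15000 nM.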

Compound 3, half-maximal cytotoxic concentration: 4900 nM
Estimate against measurement, compound 3: 1.1-fold (0.05 log units) above; the measured number falls inside the stated range.
By their numbers in this assay, from the lowest: compounds 3, 2 and 1 (each within the scatter of the next).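

In this assay, among the compounds shown here, the swap of pyrimidin-5-yl for 2-methylpyridin-4-yl gives a 1.4-fold lower number from compound 2 to compound 3 (0.14 log units; within the scatter) as the first one-place comparison in this set, and this step lies within the scatter. At this aromatic carbon, meta to two methyl groups, the read-out therefore does not separate these two six-membered aromatic rings. No evidence bears on the reason for this result.

The compounds shown leave open whether an unsubstituted pyridin-4-yl would read the same. They also leave open whether an amine or a carboxylic acid at this carbon would move the number beyond the scatter.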